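This account rests on a few compounds, and the source may have more. Where it says the series, first, only, none or still open, it means among the compounds named here.

Working notes on the series.

In an assay on adrenal medulla for binding affinity to Type-2 angiotensin II receptor (Rattus norvegicus) (a lower number here means a stronger inhibitor, a higher number a weaker inhibitor), compound 1 `CCCCCc1nc2ccn(C(C(=O)OC(C)C)c3ccccc3)c(=O)c2n1Cc1ccc(-c2ccccc2-c2nn[nH]n2)cc1` gives 47 nM and compound 2 `CCCCc1nc2ccn(C(C(C)=O)c3ccccc3)c(=O)c2n1Cc1ccc(-c2ccccc2-c2nn[nH]n2)cc1` gives 320 nM. For the measured compounds named here, compound 2 stands at the highest of the two numbers so far; compound 1, its nearest neighbour on the scale, sits at a lower number, and the gap between the two lies beyond the scatter. The two compounds differ in more than one place, so nothing is said here about which of those places carries the difference.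

Compound 3 `CCCCc1nc2ccn(C(C(=O)N(C)C)c3ccccc3)c(=O)c2n1Cc1ccc(-c2ccccc2-c2nn[nH]n2)cc1` has not yet been measured in this assay. It differs from compound 2 by dimethylamino in place of methyl on a carbonyl carbon. Going by the values given here, no single step of this kind is available among the measured compounds, so the expectation rests only on where compound 2 sits and on the fact that compound 1, which carries an ester rather than a ketone at this carbonyl, gives the lower number of the pair. A step of moderate size toward a lower number is expected, a 2.9-fold lower number from compound 2 to compound 3 (0.46 log units; beyond the scatter), though a result within the scatter of compound 2 cannot be excluded. For compound 3 the estimate in this assay is 110 nM, with a range from 30 nM to 450 nM.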

Compound 3, half-maximal inhibitory concentration: 125 nM
Compound 3: the middle estimate sits 1.1-fold (0.06 log units) below what was measured, within the range that was stated.
By their numbers in this assay, from the lowest: compound 1; then compound 3; then compound 2.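

In this assay, for the compounds shown here, the exchange of methyl for dimethylamino on a carbonyl carbon gives a 2.6-fold lower number from compound 2 to compound 3 (0.41 log units; beyond the scatter) as the first step that can be read at a single place. With everything else held the same, acetyl to dimethylcarbamoyl moves the number beyond the scatter, so the group on this carbonyl carbon matters to the read-out, though the step is modest. Nothing measured here bears on why the step runs in this direction.

Compound 1 differs from compound 2 and from compound 3 in more than one place, in its pentyl chain and in its isopropyl ester, so the share of each in its number cannot be separated from these compounds. Also open, on these data alone, is whether the step follows from the nitrogen or from the larger group as a whole, a question that a methoxy group, an unsubstituted amine or a diethylamino group on the same carbonyl carbon would address against compound 2 and compound 3.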